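Furan-2-yl for naphthalen-1-yl: working notes on the series

A few compounds are considered here, and "the series" means these few. Any claim that something is new, unique, unknown or untested is made for them only; others in the source may bear on it.

Measured so far in a functional assay on COLO 205 cells (Homo sapiens) for inhibition, read by sulforhodamine B assay, with a stated time of 48 h, tested at 50 uM (a lower number here means less inhibition of growth, a higher number more inhibition of growth at the concentration tested), for three compounds:
- compound 1 `COc1cc(/C=C/C(=O)/C=C/c2cccc3ccccc23)ccc1OCc1cn(CCOc2cc(=O)oc3ccccc23)nn1` gives 85%
- compound 2 `COc1cc(/C=C/C(=O)/C=C/c2cccc3ccccc23)ccc1OCc1cn(CCCOc2cc(=O)oc3ccccc23)nn1` gives 64%
- compound 3 `COc1ccc(/C=C/C(=O)/C=C/c2ccc(OCc3cn(CCCCOc4cc(=O)oc5ccccc45)nn3)c(OC)c2)cc1OC` gives 53%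

Compound 2 takes the middle place of the three values. Compound 3 lies lower and compound 1 lies higher, and both gaps are beyond the scatter.

The next compound to be read is compound 4 `COc1cc(/C=C/C(=O)/C=C/c2ccco2)ccc1OCc1cn(CCCOc2cc(=O)oc3ccccc23)nn1` which carries furan-2-yl in place of naphthalen-1-yl on a double-bonded chain carbon bound to a double-bonded chain carbon and is otherwise the same as compound 2.

Among the measured compounds shown here, no two measured compounds differ in one place only, so the series offers no measured step for this or any other single change. The three values show only how far the compounds spread in this assay and do not say what this exchange does. The expectation therefore stays anchored on compound 2 at 64% as the closest measured structure.

No step beyond the scatter is expected, with a slight drift downward at most. The estimated change is a number 4 percentage points lower from compound 2 to compound 4 (within the scatter) and it remains uncertain in either direction.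

Compound 4 is expected at 60% with an estimated range of 42% to 78% as the likely span.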

Compound 4, percent growth inhibition at one concentration: 59%
Estimate against measurement, compound 4: 1 percentage points above; measured number inside the range.
By their numbers in this assay, from the lowest: compounds 3, 4 and 2 (each within the scatter of the next, the first and the last beyond it); then compound 1.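

In this assay, among the compounds shown here, the exchange of furan-2-yl for naphthalen-1-yl on a double-bonded chain carbon bound to a double-bonded chain carbon gives a number 5 percentage points lower from compound 2 to compound 4 (within the scatter) and is the only single-place step the series can read so far. In this one pair, the position accepts a group of 5 heavy atoms with one five-membered aromatic ring and 1 hydrogen-bond acceptor in place of a group of 10 heavy atoms with 2 six-membered aromatic rings of carbon only, without a step beyond the scatter; the naphthalen-1-yl group is therefore not needed to keep growth inhibition at the concentration tested in this pair. Nothing at hand gives a reason for this outcome.

Going by these compounds, whether the exchange behaves the same way on the core of compound 1 or of compound 3 stays open, since this one step comes from the core of compound 2 alone. Also open, on these data alone, is how this position responds to other groups, such as phenyl, thiophen-2-yl, or a phenyl ring carrying an amine or a carboxylic acid.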